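Heteroaryl swap on the shared core, one new analogue

The compounds below may be only part of what the source reports. "The series", "measured", "known", "first", "only" and "open" are said of these compounds alone.

Among the measured compounds shown here, in an in vitro functional assay on HEK293-A cells for positive allosteric modulation of metabotropic glutamate receptor 5 (Homo sapiens), read by FLIPR and calcium flux (a lower number here means that less compound is needed, a higher number that more compound is needed for the effect), compound 1 `O=C1CC(c2nc(-c3cccc(F)c3)no2)CN1c1ccc(Cl)cc1` gives 630 nM, the higher of the two numbers measured so far. Compound 2 `Cc1ccc(N2CC(c3nc(-c4ccccc4)no3)CC2=O)cc1` gives 384 nM in this assay, which sits within the scatter of compound 1, so the two are not separable. Compound 3 `Cc1cccc(-c2noc(C3CC(=O)N(c4ccc(Cl)cc4)C3)n2)n1` differs from compound 1 in one place: 6-methylpyridin-2-yl in place of 3-fluorophenyl on an aromatic carbon. For the measured compounds named here, no measured pair isolates this change, so its size is unknown; in this assay a step beyond the scatter is not expected in either direction. The expected step of a 1.1-fold lower number from compound 1 to compound 3 (0.02 log units; within the scatter) is therefore small. Compound 3 is estimated at 600 nM, with a range of 200 nM to 2000 nM.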

Compound 3, half-maximal effective concentration: > 10000 nM
Compound 3: no number, only a limit (the forecaster's own chance of this, stated with the estimate: 10%); middle value at least 16-fold (1.22 log units) away from the limit.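

Compound 3 gives > 10000 nM in this assay, a limit of the assay and not a number. On this aromatic carbon, 6-methylpyridin-2-yl in place of 3-fluorophenyl gives an at least 15-fold higher number from compound 1 to compound 3 (1.20 log units; beyond the scatter), so the position is sensitive to the identity of the aryl group, which compounds 1 and 2 could not show. This step has a lower bound only, and its full size cannot be read: the limit of > 10000 nM in this assay, at which 1 of the 3 values shown sits.

The compounds shown do not separate the ring nitrogen from the methyl group as the source of the step. A pyridin-2-yl without the methyl, or a 3-methylphenyl, at this position would address that.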